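One Replacement on a Shared Core Toward Compound 3

The compounds below may be only part of what the source reports. "The series", "measured", "known", "first", "only" and "open" are said of these compounds alone.

Compound 1 `CS(=O)(=O)Nc1ccc(-n2cc(COc3ccc([N+](=O)[O-])cc3)nn2)cc1Oc1ccccc1`: gives "not determined" (no result reported) in a functional assay on HepG2 cells (Homo sapiens) for inhibition, read by MTT assay, with a stated time of 48 h (on this read-out lower numbers stand for stronger inhibition and higher numbers for weaker inhibition), so no result is reported for it.
Compound 2 `Cc1ccc(-c2cn(-c3ccc(NS(C)(=O)=O)c(Oc4ccccc4)c3)nn2)cc1`: gives 18300 nM in this assay.

Within the data shown here, compound 2 stands alone: its value is the only number in this assay, and compound 1 contributes no result at all. Nothing can therefore be read about how any change on this core shifts the read-out. Compound 3 `CS(=O)(=O)Nc1ccc(-n2cc(COc3ccccc3Cl)nn2)cc1Oc1ccccc1` differs from compound 2 in one place: (2-chlorophenoxy)methyl in place of 4-methylphenyl on an aromatic carbon. Among the measured compounds shown here, with no measured step between compounds that differ in a single position, the size and direction of this change cannot be taken from the data. The account accordingly expects a step from compound 2 to compound 3 of a 1.2-fold lower number from compound 2 to compound 3 (0.09 log units; within the scatter), which is no more than the usual scatter. Compound 3 is estimated at 15000 nM in this assay, with a range from 4000 nM to 50000 nM.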

Compound 3, half-maximal inhibitory concentration: 25300 nM
Compound 3: the middle estimate sits 1.7-fold (0.23 log units) below what was measured; the range from low to high includes it.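

In this assay, among these compounds, the first readable step at this position is a 1.4-fold higher number from compound 2 to compound 3 (0.14 log units; within the scatter), so the two compounds cannot be told apart on this read-out. On this aromatic carbon of the five-membered ring, then, (2-chlorophenoxy)methyl and 4-methylphenyl give values within the scatter of each other, even though the entering group brings an oxygen and a chlorine and has a hydrogen-bond acceptor that the leaving group lacks. Nothing given here accounts for this result.

Still open, as far as these compounds go, is whether a group such as an amine or a carboxylic acid on this carbon would shift the number beyond the scatter. Also open is whether the chlorine on the phenoxy ring matters, as a plain phenoxymethyl group is not among the compounds shown.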